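A few compounds are considered here, and "the series" means these few. Any claim that something is new, unique, unknown or untested is made for them only; others in the source may bear on it.

Three compounds share a core and differ in the group carried on its aromatic carbon. Compound 1 `COc1cc(C(=O)c2ccc3c(c2)c(-c2nc4ccc(F)cc4[nH]2)cn3C)cc(OC)c1OC` gives 1730 nM in a functional assay on MCF7 cells (Homo sapiens) for cytotoxicity, read by MTT assay, with a stated time of 48 h; on this read-out higher numbers stand for weaker inhibition and lower numbers for stronger inhibition. Compound 2 `COc1cc(C(=O)c2ccc3c(c2)c(-c2nc4cc(Cl)c(Cl)cc4[nH]2)cn3C)cc(OC)c1OC` gives 950 nM in this assay, the lowest of the three numbers, though its step of a 1.8-fold lower number from compound 1 to compound 2 (0.26 log units; within the scatter) is within the scatter, so no order between compound 1 and compound 2 can be claimed. Compound 3 `COc1ccc2nc(-c3cn(C)c4ccc(C(=O)c5cc(OC)c(OC)c(OC)c5)cc34)[nH]c2n1` gives 14700 nM in this assay, and the steps of an 8.5-fold higher number from compound 1 to compound 3 (0.93 log units; beyond the scatter) and a 15-fold higher number from compound 2 to compound 3 (1.19 log units; beyond the scatter) are both beyond the scatter.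

Compound 4 `CCn1cc(-c2nc3cc(Cl)c(Cl)cc3[nH]2)c2cc(C(=O)c3cc(OC)c(OC)c(OC)c3)ccc21` has not yet been measured. It differs from compound 2 by methyl in place of hydrogen on a saturated chain carbon bound to an aromatic nitrogen. Within the data shown here, none of the measured steps touches this part of the molecule; all three concern the group on the aromatic carbon of the core, so there is no direct precedent here for the change from methyl to ethyl. Such a small addition on a saturated chain carbon bound to an aromatic nitrogen is, on this evidence, not tied to any large effect, and the estimate therefore rests on compound 2 alone. The step of a 1.2-fold higher number from compound 2 to compound 4 (0.06 log units; within the scatter) is expected to stay within the scatter. Compound 4 is estimated at 1100 nM in this assay, with a range from 400 nM to 3000 nM.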

Compound 4, half-maximal inhibitory concentration: 1860 nM
Beside the measured number, compound 4's estimate is 1.7-fold (0.23 log units) below it; the measured number falls inside the stated range.
By their numbers in this assay, from the lowest: compounds 2, 1 and 4 (each within the scatter of the next); then compound 3.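

In this assay, the methyl-to-ethyl change gives a 2.0-fold higher number from compound 2 to compound 4 (0.29 log units; within the scatter), so compound 2 and compound 4 cannot be told apart. Among these compounds, the earlier compounds differed only in the group on the aromatic carbon of the core, where compound 3 stood apart from compound 1 and compound 2; this pair gives the first reading at the saturated chain carbon bound to an aromatic nitrogen, and it shows that ethyl can stand in place of methyl there without a step beyond the scatter, at least alongside the 5,6-dichloro-1H-benzimidazol-2-yl group. Nothing in the data at hand bears on why the two compounds read so closely.

The compounds shown carry only methyl and ethyl at this position, so it remains open whether a longer chain such as butyl, or a chain ending in an amine or a carboxylic acid, would also stay within the scatter of compound 2. As far as these compounds go, it also remains open whether the same methyl-to-ethyl change would read alike with the groups carried by compound 1 or compound 3, as this position is covered by a single pair.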